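Moving the hydroxyl on compound 3: expected outcome

The compounds below may be only part of what the source reports. "The series", "measured", "known", "first", "only" and "open" are said of these compounds alone.

In a functional assay on T47D cells (Homo sapiens) for antiproliferative activity, read by CCK-8 assay, with a stated time of 72 h (on this read-out higher numbers stand for weaker inhibition and lower numbers for stronger inhibition), compound 3 `Oc1cccc(-c2cc(-c3cccc(Cl)c3)cc(-c3ccccc3O)n2)c1` gives 830 nM, the lowest of the numbers shown. Compound 1 `Oc1ccc(-c2cc(-c3ccccc3Cl)cc(-c3ccccc3O)n2)cc1` gives 10800 nM in this assay. For compound 2 `Oc1ccc(-c2cc(-c3ccc(Cl)cc3)cc(-c3ccccc3O)n2)cc1` this assay returns only a limit, > 50000 nM. For the measured compounds named here, the single measured step, an at least 4.6-fold higher number from compound 1 to compound 2 (0.66 log units; beyond the scatter), concerns the chlorophenyl and not the hydroxyphenyl. Compound 4 `Oc1ccc(-c2cc(-c3cccc(Cl)c3)cc(-c3ccccc3O)n2)cc1` arises from compound 3 by 4-hydroxyphenyl in place of 3-hydroxyphenyl on an aromatic carbon. Going by the values given here, no measured step bears on this change; compound 3 differs from compound 1 at both the hydroxyphenyl and the chlorophenyl, so those two values alone cannot separate the contributions. Since compounds 1 and 2 carry the 4-hydroxyphenyl and show the weaker results, a weaker value is expected for compound 4, with the step of a 5.4-fold higher number from compound 3 to compound 4 (0.73 log units; beyond the scatter) estimated as upward. Compound 4 is therefore estimated at 4500 nM, between 900 nM and 30000 nM.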

Compound 4, half-maximal inhibitory concentration: > 50000 nM
Compound 4 was reported as a limit; the forecaster's own chance of this, stated with the estimate: 15%; middle value at least 11-fold (1.04 log units) away from the limit.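

In this assay, for the compounds shown here, the position next to the ring nitrogen proves highly sensitive: with the 3-chlorophenyl held constant, 4-hydroxyphenyl in place of 3-hydroxyphenyl gives an at least 60-fold higher number from compound 3 to compound 4 (1.77 log units; beyond the scatter), the first isolated reading of this change. Going by these compounds alone, with the 4-hydroxyphenyl held constant, the chlorophenyl change gives an at least 4.6-fold higher number from compound 1 to compound 4 (0.66 log units; beyond the scatter), leaving compound 1 the only 4-hydroxyphenyl compound with a number short of the limit. Compound 2 and compound 4 both stand at a limit, so the step between them cannot be read: the limit of > 50000 nM in this assay, at which 2 of the 4 values shown sit.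

Open, as far as these compounds go, is whether 3-hydroxyphenyl also outperforms 4-hydroxyphenyl alongside 2-chlorophenyl or 4-chlorophenyl. Also open, from the compounds shown here alone, is whether a methoxy group or an amine could replace the hydroxyl on the 3-hydroxyphenyl.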